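A few compounds are considered here, and "the series" means these few. Any claim that something is new, unique, unknown or untested is made for them only; others in the source may bear on it.

Measured so far:
compound 1, `Brc1ccc2ccn(CCN3CCNCC3)c2c1`: 61%
compound 2, `CN1CCCN(CCn2ccc3ccc(Cl)cc32)CC1`: 85%

In an assay on HEK293 cells for binding affinity to 5-hydroxytryptamine receptor 7 (Homo sapiens), read by radioligand binding, tested at 1 uM (a higher number here means more inhibition at the concentration tested (going by the name of the read-out), a lower number less inhibition), compound 1 gives 61% and compound 2 gives 85%. Compound 2 thus stands highest of the two numbers recorded; the nearest is compound 1, whose number lies lower by a gap beyond the usual scatter of repeated measurements. For the measured compounds named here, the two compounds differ from each other in more than one place, so no single step can be drawn between them, and nothing beyond the two values themselves is said of that pair.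

Compound 3, `CN1CCCN(CCn2ccc3ccc(-c4cccnc4)cc32)CC1`, has not yet been measured in this assay. Relative to compound 2 the change is pyridin-3-yl in place of chloro on an aromatic carbon. With no measured step of this kind in the series, the size of the step is open in either direction. The expectation is a modest loss rather than a gain, since compound 2 already sits high in this assay at 85% and leaves little room above. The expected step from compound 2 to compound 3 is a number 13 percentage points lower from compound 2 to compound 3 (beyond the scatter). For compound 3 the estimate in this assay is 72%, with a range from 45% to 95%.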

Compound 3, a percentage reported as inhibition, at one concentration (the size of the read-out at that concentration, not a potency): 35%
For compound 3 the middle estimate is 37 percentage points above the measured one, and the stated range ends above it.
By their numbers in this assay, from the lowest: compound 3; then compound 1; then compound 2.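

In this assay, the aromatic carbon meta to a fused ring and para to a fused ring proves sensitive to what it carries: exchanging chloro, a single heavy atom, for pyridin-3-yl, with 6 heavy atoms and one six-membered aromatic ring, gives a number 50 percentage points lower from compound 2 to compound 3 (beyond the scatter), classed as a large step. For the compounds shown here, this is the only single-place comparison so far, and it shows that the high number of compound 2 does not carry over to this aromatic replacement, even with the rest of the structure held constant. Nothing available explains the size of this step, which therefore stands as an observation without an assigned cause.

A single pair cannot separate the contribution of the ring nitrogen from that of the added aromatic ring; phenyl or pyridin-4-yl on the same carbon would address that question. Also open, on these data alone, is how the number responds to smaller replacements for chloro, such as fluoro, methyl or methoxy, and therefore whether it falls gradually or abruptly across groups of intermediate size.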